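The source may hold more compounds than are shown below. What is called first, only, known or untested is meant among the compounds shown, and "the series" means these compounds.

Measured so far in an assay for inhibition of ribosomal protein S6 kinase beta-1 variant D18H,T412E (Homo sapiens), read by a luciferase reporter and chemiluminescence, with a stated time of 3 h; a higher number here means a weaker inhibitor, a lower number a stronger inhibitor:
- compound 1, `Nc1ncnc(N2CCN(c3cccc(Cl)c3)CC2)c1[N+](=O)[O-]`: 85 nM
- compound 2, `Cc1ccc(Cl)cc1N1CCN(c2ncnc(N)c2[N+](=O)[O-])CC1`: 3 nM
- compound 3, `CCc1n[nH]c2ncnc(N3CCN(c4cc(Cl)ccc4C)CC3)c12`: 6 nM

Compound 3 sits second highest of the three numbers in this assay. Its nearest neighbour is compound 2, whose value lies within the scatter of that of compound 3, so no order between the two is claimed. The furthest is compound 1, which gives a higher number than compound 3, and that gap lies beyond the scatter.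

Among the compounds with values here, the one single-point step measured in the set is a 28-fold lower number from compound 1 to compound 2 (1.45 log units; beyond the scatter). It concerns the aryl ring on the piperazine and is kept constant between compound 3 and compound 4, so it does not speak to the change under study.

Compound 4, `Cc1ccc(Cl)cc1N1CCN(c2ncnc3[nH]nc(C(F)(F)F)c23)CC1`, differs from compound 3 only in this: trifluoromethyl in place of ethyl on an aromatic carbon. Within the data shown here, no measured pair varies the group on the five-membered aromatic ring with 2 nitrogen, so there is no step in this assay from which to read a direction. The expectation is therefore a step of no change at the digits printed from compound 3 to compound 4 (within the scatter), with no change beyond the scatter anticipated.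

On that basis compound 4 is estimated at 6 nM in this assay, with a range from 2 nM to 20 nM.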

Compound 4, half-maximal inhibitory concentration: 29 nM
The estimate for compound 4 lay 4.8-fold (0.68 log units) below the measured number; measured number above the stated range.
By their numbers in this assay, from the lowest: compounds 2 and 3 (each within the scatter of the next); then compound 4; then compound 1.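

In this assay, within the data shown here, the group on the aromatic carbon of the five-membered aromatic ring with 2 nitrogen now has a measured effect: trifluoromethyl in place of ethyl gives a 4.8-fold higher number from compound 3 to compound 4 (0.68 log units; beyond the scatter) and this is the first step to vary this position. The position is therefore not indifferent to the group it carries, and of the two groups shown, ethyl gives the lower number, although this step is smaller than the change on the aryl ring, a 28-fold lower number from compound 1 to compound 2 (1.45 log units; beyond the scatter) in the same assay. No measurement at hand gives a reason for the step at this position.

Going by these compounds, two groups at one carbon define no trend, so it remains open whether hydrogen, methyl, a longer chain such as propyl, a cyclopropyl ring, an amine or a nitrile would give a number nearer that of ethyl or that of trifluoromethyl. On these data alone, compound 3 and compound 4 also share one aryl ring on the piperazine, so it remains open whether the same exchange would give a step of similar size with the aryl ring of compound 1.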